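The source may hold more compounds than are shown below. What is called first, only, known or untested is meant among the compounds shown, and "the series" means these compounds.

Values in a physicochemical assay for solubility, measured as kinetic solubility, with a stated time of 1 h, at pH 7.4; a lower number here means a less soluble compound, a higher number a more soluble compound:
- compound 1 `CC(=O)Nc1nc(-c2ccc(Cl)cc2)cs1`: 1000 nM
- compound 2 `CC(=O)Nc1nc(-c2ccc(Cl)c(F)c2)cs1`: 5000 nM
- compound 3 `CC(=O)Nc1nc(-c2ccc(Cl)c(C)c2)cs1`: not yet measured

Compound 2 holds the higher of the two numbers, at 5000 nM. The next change is methyl in place of fluoro on an aromatic carbon. Going by the values given here, only one measured step bears on it: a 5.0-fold higher number from compound 1 to compound 2 (0.70 log units; beyond the scatter), a modest step beyond the scatter, with fluoro in place of hydrogen. Among the compounds with values here, no measured compound carries methyl, so this assay is expected to give back part of that gain. The estimated step is a 2.8-fold lower number from compound 2 to compound 3 (0.44 log units; beyond the scatter), of modest size towards a lower number. The estimate for compound 3 is 1800 nM, with an expected range of 500 nM to 6000 nM.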

Compound 3, solubility: 1000 nM
Compound 3: the middle estimate sits 1.8-fold (0.26 log units) above what was measured, and the stated range covers the measured number.
By their numbers in this assay, from the lowest: compounds 1 and 3 (each within the scatter of the next); then compound 2.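

In this assay, the place ortho to a chloro group responds to which group enters it: a 5.0-fold lower number from compound 2 to compound 3 (0.70 log units; beyond the scatter), so the rise seen with fluoro does not carry over to methyl. Against hydrogen, methyl gives no change at the digits printed from compound 1 to compound 3 (within the scatter), which leaves fluoro as the only one of the three groups here with a higher number. Nothing at hand speaks to the cause of this difference.

Open, from the compounds shown here alone, is whether methoxy, nitrile or bromo at this place would follow fluoro or methyl. Also open, going by these compounds, is whether the fluoro step holds when the chloro group is absent.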